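Aminoalkyl triazole in place of methyl triazole

The source may report more compounds than this note shows. Statements on the series, on what has been measured and on what is new or still open speak of the compounds shown alone.

Compound 1 `Cn1ncnc1-c1cc(Oc2ccc(NC(=O)Nc3cccc(C(F)(F)F)c3)cc2F)ccn1` is the reference point of the set. In a functional assay on MDA-MB-231 cells (Homo sapiens) for antiproliferative activity, read by MTT assay, with a stated time of 72 h (on this read-out higher numbers stand for weaker inhibition and lower numbers for stronger inhibition), compound 1 gives 9680 nM, the highest number among the three measured. Compound 2 `CN(C)CCn1cnnc1-c1cc(Oc2ccc(NC(=O)Nc3ccc(Cl)c(C(F)(F)F)c3)cc2F)ccn1` gives 1070 nM in this assay, and compound 3 `CCN(CC)CCn1cnnc1-c1cc(Oc2ccc(NC(=O)Nc3ccc(Cl)c(C(F)(F)F)c3)cc2F)ccn1` gives 1540 nM; both numbers lie beyond the scatter from compound 1, but each of these compounds differs from compound 1 at the five-membered ring and also at a second place, so the gap cannot be assigned to the ring change alone. Among the compounds with values here, the one single-site step on record is a 1.4-fold higher number from compound 2 to compound 3 (0.16 log units; within the scatter), which shows dimethylamino and diethylamino giving numbers within the scatter of each other.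

Compound 4 `CN(C)CCCn1cnnc1-c1cc(Oc2ccc(NC(=O)Nc3cccc(C(F)(F)F)c3)cc2F)ccn1` is not yet measured. It differs from compound 1 by 4-(3-(dimethylamino)propyl)-4H-1,2,4-triazol-3-yl in place of 1-methyl-1H-1,2,4-triazol-5-yl on an aromatic carbon, with everything else as in compound 1. Compounds 2 and 3, which carry an aminoalkyl chain on the five-membered ring, sit well below compound 1, which supports a decrease, though part of their gap may come from the second change. The expected step in this assay is therefore a 3.9-fold lower number from compound 1 to compound 4 (0.59 log units; beyond the scatter), toward a lower number. Compound 4 is estimated at 2500 nM, with a range from 800 nM to 8000 nM.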

Compound 4, half-maximal inhibitory concentration: 13300 nM
For compound 4 the middle estimate is 5.3-fold (0.73 log units) below the measured one, and the stated range ends below it.
By their numbers in this assay, from the lowest: compounds 2 and 3 (each within the scatter of the next); then compounds 1 and 4 (each within the scatter of the next).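

In this assay, within the data shown here, the first single-site reading at this position, on an aromatic carbon next to the ring nitrogen, is a 1.4-fold higher number from compound 1 to compound 4 (0.14 log units; within the scatter) and stands within the scatter. The position therefore takes 4-(3-(dimethylamino)propyl)-4H-1,2,4-triazol-3-yl in place of 1-methyl-1H-1,2,4-triazol-5-yl with no measurable shift on this read-out, so this change alone shows no gain in inhibition. No measured evidence on hand accounts for this outcome.

Among these compounds, no single-site pair isolates the chlorine carried by compounds 2 and 3, so its contribution, alone or together with the aminoalkyl triazole, stays open. Also open, on these data alone, is how a morpholine or a carboxylic acid at the end of the chain would read in this assay on the core of compound 1.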